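The source may hold more compounds than are shown below. What is called first, only, known or untested is meant among the compounds shown, and "the series" means these compounds.

The series shares one core, seen in compound 1 `O=C(/C=C/c1ccc2c(c1)B(O)OC2)c1cccnc1`, compound 2 `O=C(/C=C/c1ccc2c(c1)B(O)OC2)c1ccc(C(F)(F)F)cc1` and compound 3 `CCOC(=O)c1ccc(C(=O)/C=C/c2ccc3c(c2)B(O)OC3)cc1`, which differ only in the aromatic ring on the carbonyl carbon. In a functional assay on MDA-MB-231 cells (Homo sapiens) for cytotoxicity, read by MTT assay, with a stated time of 48 h (on this read-out lower numbers stand for stronger inhibition and higher numbers for weaker inhibition), compound 1 gives 11400 nM, compound 2 gives 9200 nM and compound 3 gives 13000 nM; all three numbers sit within the scatter of each other, so compound 1 stands level with the rest. Compound 4 `O=C(/C=C/c1ccc2c(c1)B(O)OC2)c1cccc(F)c1` carries 3-fluorophenyl in place of pyridin-3-yl on a carbonyl carbon. Going by the values given here, the only measured step on the carbonyl-side ring, a 1.4-fold higher number from compound 2 to compound 3 (0.15 log units; within the scatter), lies within the scatter, and it alters a substituent rather than exchanging the ring itself, so it bears only loosely on this change. No step beyond the scatter is therefore expected. The expected step is a 1.1-fold lower number from compound 1 to compound 4 (0.04 log units; within the scatter). Compound 4 is estimated at 10500 nM, with a range from 5000 nM to 22000 nM.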

Compound 4, half-maximal inhibitory concentration: 3000 nM
Estimate against measurement, compound 4: 3.5-fold (0.54 log units) above; measured number below the stated range.
By their numbers in this assay, from the lowest: compound 4; then compounds 2, 1 and 3 (each within the scatter of the next).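

Going by these compounds alone, the carbonyl-side ring is the first place where a change clears the scatter in this assay: 3-fluorophenyl in place of pyridin-3-yl on a carbonyl carbon gives a 3.8-fold lower number from compound 1 to compound 4 (0.58 log units; beyond the scatter) and sets compound 4 apart. Compounds 1, 2 and 3 stood level and showed no such sensitivity at this position. Nothing available explains the step.

The exchange removes the ring nitrogen and adds fluorine at once, so the compounds shown do not separate the two. As far as these compounds go, whether a plain phenyl ring would keep the lower number, and whether chlorine or a methoxy group could replace the fluorine, stays open.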